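Replacing the 4-hydroxyphenyl group of compound 3

The source may hold more compounds than are shown below. What is called first, only, known or untested is meant among the compounds shown, and "the series" means these compounds.

Compound 1 `O=S(=O)(/C=C/c1ccc(C(F)(F)F)cc1F)Cc1ccc(Nc2ncnc3ccccc23)cc1`: 100000 nM
Compound 2 `O=S(=O)(/C=C/c1ccc(Cl)c(Cl)c1)Cc1ccc(Nc2ncnc3ccc(Br)cc23)cc1`: 30000 nM
Compound 3 `O=S(=O)(/C=C/c1ccc(O)cc1)Cc1ccc(Nc2ncnc3ccc(Br)cc23)cc1`: 28000 nM

These three compounds were tested in a functional assay on UACC-62 cells (Homo sapiens); a lower number here means a stronger inhibitor of growth, a higher number a weaker inhibitor of growth. Among the measured compounds shown here, the only measured step between them is a 1.1-fold lower number from compound 2 to compound 3 (0.03 log units; within the scatter). Compound 3 therefore stands level with compound 2, and the number for compound 1 is clearly higher. The next compound, compound 4 `O=S(=O)(/C=C/c1ccc(C(F)(F)F)cc1F)Cc1ccc(Nc2ncnc3ccc(Br)cc23)cc1`, carries a change from compound 3: 2-fluoro-4-(trifluoromethyl)phenyl in place of 4-hydroxyphenyl on a double-bonded chain carbon bound to a double-bonded chain carbon. This group also sits on compound 1, but the core of compound 1 differs from the core shared by compounds 2, 3 and 4. For the measured compounds named here, only the step to compound 3 bears directly on the change, and it shows two different groups in this place giving values within the scatter. The high value of compound 1 leaves some room upward, so no step beyond the scatter is expected. The estimated step is a 1.3-fold higher number from compound 3 to compound 4 (0.10 log units; within the scatter). Compound 4 is expected at 35000 nM, with an estimated range from 13000 nM to 90000 nM.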

Compound 4, concentration for 50% growth inhibition: 22000 nM
Estimate against measurement, compound 4: 1.6-fold (0.20 log units) above; low and high end bracket the measured number.
By their numbers in this assay, from the lowest: compounds 4, 3 and 2 (each within the scatter of the next); then compound 1.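

In this assay, a 1.3-fold lower number from compound 3 to compound 4 (0.10 log units; within the scatter) and a 1.4-fold lower number from compound 2 to compound 4 (0.13 log units; within the scatter), so three differently substituted phenyl groups on this double-bonded chain carbon now sit within the scatter of one another, even though 2-fluoro-4-(trifluoromethyl)phenyl has none of the hydrogen-bond donors or acceptors of 4-hydroxyphenyl. Among the compounds shown here, with 2-fluoro-4-(trifluoromethyl)phenyl held fixed, there is a 4.5-fold lower number from compound 1 to compound 4 (0.66 log units; beyond the scatter), so the only step beyond the scatter comes from bromo in place of hydrogen on an aromatic carbon, not from a change at this position. Nothing available explains either result.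

On these data alone, whether an amine or a carboxylic acid at this position would move the number beyond the scatter stays open. For the compounds shown here, the bromo step is seen only with 2-fluoro-4-(trifluoromethyl)phenyl, so whether it holds with other groups also stays open.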